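Side-chain substituents on the core of compound 1

The source may hold more compounds than are shown below. What is called first, only, known or untested is meant among the compounds shown, and "the series" means these compounds.

Compound 1 `CCc1c(F)c(N)c2c(=O)cc(-c3ccc(N)c(F)c3)oc2c1F` sits at the limit of a functional assay on HeLa cells (Homo sapiens) for cytotoxicity, read by neutral red uptake, with a stated time of 3 days (on this read-out lower numbers stand for stronger inhibition and higher numbers for weaker inhibition), returning > 100000 nM; this is a limit, not a number. Compound 2 `Nc1ccc(-c2cc(=O)c3c(N)c(F)c(CO)c(F)c3o2)cc1F` gives 24000 nM in this assay. Compound 3 `Nc1ccc(-c2cc(=O)c3c(N)c(F)c(C(=O)O)c(F)c3o2)cc1F` returns only a limit in this assay, > 100000 nM. The readable steps are an at least 4.1-fold lower number from compound 1 to compound 2 (0.61 log units; beyond the scatter) and an at least 4.1-fold higher number from compound 2 to compound 3 (0.61 log units; beyond the scatter); the step that the two limits leave unreadable from compound 1 to compound 3 cannot be sized because the limit of > 100000 nM in this assay, at which 2 of the 3 values shown sit, holds both of its ends.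

Compound 4 `NCc1c(F)c(N)c2c(=O)cc(-c3ccc(N)c(F)c3)oc2c1F` differs from compound 1 by amino in place of methyl on a saturated chain carbon bound to an aromatic carbon. The step from compound 1 to compound 2 bears on this change, as it likewise replaces the methyl on the saturated chain carbon and lowered the number beyond the scatter. A lower number of comparable, modest size is therefore expected in this assay. Compound 4 is expected at 30000 nM, within 8000 nM to 100000 nM, an expected step of an at least 3.3-fold lower number from compound 1 to compound 4 (0.52 log units; beyond the scatter).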

Compound 4, half-maximal inhibitory concentration: 8800 nM
The estimate for compound 4 lay 3.4-fold (0.53 log units) above the measured number; the measured number falls inside the stated range.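

In this assay, amino in place of methyl on the saturated chain carbon gives an at least 11-fold lower number from compound 1 to compound 4 (1.05 log units; beyond the scatter), and aminomethyl in place of carboxy gives an at least 11-fold lower number from compound 3 to compound 4 (1.05 log units; beyond the scatter). Amino in place of hydroxy at the same carbon still gives a 2.7-fold lower number from compound 2 to compound 4 (0.44 log units; beyond the scatter), so hydroxy was not the end of the trend at this position. Compound 4 is the strongest of the four compounds.

From the compounds shown here alone, the two large steps each start from a limit, so their full size stays open: the limit of > 100000 nM in this assay, at which 2 of the 4 values shown sit. Whether a dimethylamino group or a longer chain ending in an amine goes further also remains open.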